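Swapping chloro for ethoxy in an antiproliferative series

This account rests on a few compounds, and the source may have more. Where it says the series, first, only, none or still open, it means among the compounds named here.

In a functional assay on FM3A cells (Mus musculus) for antiproliferative activity, with a stated time of 48 h (on this read-out higher numbers stand for weaker inhibition and lower numbers for stronger inhibition), compound 1 (`C=C(Br)C(=O)Nc1ccc(/C=C/C(=O)c2ccc(Cl)cc2)cc1`) gives 1300 nM. Compound 3 (`C=C(Br)C(=O)Nc1ccc(/C=C/C(=O)c2cc(OC)c(OC)c(OC)c2)cc1`) gives 950 nM, within the scatter of compound 1, and compound 2 (`C=C(Br)C(=O)Nc1ccc(/C=C/C(=O)c2cccc(OC)c2)cc1`) gives 2700 nM. Compound 4 (`C=C(Br)C(=O)Nc1ccc(/C=C/C(=O)c2ccc(OCC)cc2)cc1`) differs from compound 1 by ethoxy in place of chloro on an aromatic carbon, with ethoxy in place of chloro on an aromatic carbon. Going by the values given here, one measured step bears on this change, since it also removes the 4-chlorophenyl group, putting 3-methoxyphenyl there: a 2.1-fold higher number from compound 1 to compound 2 (0.32 log units; beyond the scatter), a modest rise in the number. A similarly small upward move is therefore expected, a 1.3-fold higher number from compound 1 to compound 4 (0.12 log units; within the scatter), which may not clear the scatter. Compound 4 is estimated at 1700 nM, with an expected range from 700 nM to 4000 nM.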

Compound 4, half-maximal inhibitory concentration: 680 nM
Compound 4: middle estimate off by 2.5-fold (0.40 log units), on the high side; measured number outside the range, below it.
By their numbers in this assay, from the lowest: compounds 4, 3 and 1 (each within the scatter of the next); then compound 2.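

In this assay, ethoxy in place of chloro, para to a large group, gives a 1.9-fold lower number from compound 1 to compound 4 (0.28 log units; within the scatter), so the added heavy atoms and the hydrogen-bond acceptor bring no change that clears the scatter. Unlike a 2.1-fold higher number from compound 1 to compound 2 (0.32 log units; beyond the scatter), which replaced the whole 4-chlorophenyl group, this step alters only the group on that aromatic carbon. Nothing shown gives a reason for this result. On these data alone, whether a longer chain such as butoxy, an amine or a carboxylic acid would also stay within the scatter of compound 1 remains open.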